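The source may report more compounds than this note shows. Statements on the series, on what has been measured and on what is new or still open speak of the compounds shown alone.

In a functional assay (aorta) with Rattus norvegicus as the target, in the presence of a further agent that is not named here (on this read-out lower numbers stand for an effect already at smaller amounts and higher numbers for an effect only at larger amounts of compound), compound 1 `COC(=O)C1=C(C)N=C(C)/C(=C(/O)OC)C1c1cccc(OCc2nonc2C(N)=O)c1` gives 3500 nM and compound 2 `COC(=O)C1=C(C)N=C(C)/C(=C(/O)OC)C1c1ccccc1OCc1c(C)no[n+]1[O-]` gives 78 nM as the lower of the two numbers, by a gap beyond the scatter. Compound 3 `COC(=O)C1=C(C)N=C(C)/C(=C(/O)OC)C1c1ccccc1OCc1no[n+]([O-])c1C(N)=O` has not yet been measured. It keeps the core of compound 2 and swaps one group on a saturated chain carbon bound to an oxygen on an aromatic ring (a group of 9 heavy atoms (3 carbon, 3 nitrogen, 3 oxygen; one five-membered aromatic ring with 3 hetero atoms) in place of a group of 7 heavy atoms (3 carbon, 2 nitrogen, 2 oxygen; one five-membered aromatic ring with 3 hetero atoms), on a saturated chain carbon bound to an oxygen on an aromatic ring). Among the measured compounds shown here, no measured step shows what such a swap does. In this assay a small rise in the number is therefore expected, a 1.5-fold higher number from compound 2 to compound 3 (0.19 log units; within the scatter) and within the scatter. Compound 3 is estimated at 120 nM (expected range 30 nM to 500 nM).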

Compound 3, half-maximal effective concentration: 550 nM
Compound 3: the middle estimate sits 4.6-fold (0.66 log units) below what was measured; measured number outside the range, above it.
By their numbers in this assay, from the lowest: compound 2; then compound 3; then compound 1.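

In this assay, the swap of the group of 7 heavy atoms for the group of 9 heavy atoms, on a saturated chain carbon bound to an oxygen on an aromatic ring, gives a 7.1-fold higher number from compound 2 to compound 3 (0.85 log units; beyond the scatter). This first single-place step shows that the read-out responds to a change at this position, even though both groups contain a five-membered aromatic ring with 3 hetero atoms. No available data explain the rise. On these data alone, the entering group differs from the leaving group in several features, so the feature responsible remains unknown. Also open, as far as these compounds go, is how an amine, a carboxylic acid or a longer chain would behave at this position.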